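A few compounds are considered here, and "the series" means these few. Any claim that something is new, unique, unknown or untested is made for them only; others in the source may bear on it.

Compounds measured in a functional assay on MGC-803 cells (Homo sapiens) for antiproliferative activity, read by CCK-8 assay, with a stated time of 72 h, tested at 8 uM; a lower number here means a weaker effect, a higher number a stronger effect of the compound at the concentration tested:

Compound 1, `CCN(Cc1ccncc1)C(=S)SCc1ccc(C(=O)Nc2ccccc2N)cc1`, gives 85.2%.
Compound 2, `Nc1ccccc1NC(=O)c1ccc(CSC(=S)N2CCN(Cc3ccncc3)CC2)cc1`, gives 79.3%.
Compound 3, `Nc1ccccc1NC(=O)c1ccc(CSC(=S)N2CCc3cc(Cl)ccc32)cc1`, gives 82.2%.

The three numbers lie within the scatter of one another, so none is separated from the rest; compound 2 differs from compound 3 and from compound 1 only by amounts within the scatter. For the measured compounds named here, the step from compound 1 to compound 3, a number 3 percentage points lower from compound 1 to compound 3 (within the scatter), is the one measured step, and it replaces the whole group on the thiocarbonyl carbon without moving the number beyond the scatter. Compound 4, `Nc1ccccc1NC(=O)c1ccc(CSC(=S)N2CCN(c3ncccn3)CC2)cc1`, has not been measured. Its difference from compound 2 is pyrimidin-2-yl in place of (pyridin-4-yl)methyl on an amine nitrogen in a ring. Going by the values given here, no measured step touches this ring nitrogen, but the values of compound 1 and compound 2 show that reshaping the amine part leaves the number inside the scatter. The step is therefore expected to be an estimated a number 1.3 percentage points lower from compound 2 to compound 4 (within the scatter). Compound 4 is estimated to give 78%, in a range from 66% to 88%.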

Compound 4, a percentage reported as inhibition, at one concentration (the size of the read-out at that concentration, not a potency): 64.8%
For compound 4 the middle estimate is 13.2 percentage points above the measured one, and the stated range ends above it.
By their numbers in this assay, from the lowest: compound 4; then compounds 2, 3 and 1 (each within the scatter of the next).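

For the compounds shown here, the step of a number 14.5 percentage points lower from compound 2 to compound 4 (beyond the scatter) shows that in this assay the group on this ring nitrogen can matter, since it is the only step here that lies beyond the scatter. Going by these compounds alone, the one earlier measured step replaced the whole group on the thiocarbonyl carbon and stayed within the scatter, whereas this narrower change, pyrimidin-2-yl in place of (pyridin-4-yl)methyl, does not. No measurement at hand explains this step.

The two groups differ both in the methyl link and in the ring itself, so the compounds shown leave open which of these differences carries the step. A benzyl or a phenyl group on the same ring nitrogen would help to separate the two, and a pyrimidin-2-ylmethyl group would test the ring with the link kept.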